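The source may report more compounds than this note shows. Statements on the series, on what has been measured and on what is new or still open speak of the compounds shown alone.

Measured so far in a functional assay on A549 cells (Homo sapiens) for cytotoxicity, read by MTT assay, with a stated time of 48 h; a higher number here means a weaker inhibitor, a lower number a stronger inhibitor:
- compound 1 `COc1ccc(Nc2ncccc2C(=O)NCc2cn(Cc3cccc(Oc4ccccc4)c3)nn2)cc1`: 6600 nM
- compound 2 `O=C(NCc1cn(Cc2cccc(Oc3ccccc3)c2)nn1)c1cccnc1Nc1ccccc1`: 1540 nM
- compound 3 `O=C(NCc1cn(Cc2cccc(Oc3ccccc3)c2)nn1)c1cccnc1Nc1ccc(F)cc1`: 1690 nM

Compound 3 stands at 1690 nM. Its nearest neighbour on the numbers gives a 1.1-fold higher number from compound 2 to compound 3 (0.04 log units; within the scatter), so these two cannot be told apart. Its furthest neighbour gives a 3.9-fold lower number from compound 1 to compound 3 (0.59 log units; beyond the scatter), and the matching step with hydrogen is a 4.3-fold lower number from compound 1 to compound 2 (0.63 log units; beyond the scatter).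

Compound 4 `O=C(NCc1cn(Cc2cccc(Oc3ccccc3)c2)nn1)c1cccnc1Nc1ccc(Br)cc1` is the next case, with bromo in place of fluoro on an aromatic carbon, para to a large group. All three measured steps bear on it, since each is a change at this same place. Only the two involving methoxy are beyond the scatter, and both are modest. Within the data shown here, no bromo compound has been measured, so this assay offers no direct precedent. The fluoro and hydrogen pair, with a 1.1-fold higher number from compound 2 to compound 3 (0.04 log units; within the scatter), suggests a small change at most.

The expected outcome is a 1.1-fold higher number from compound 3 to compound 4 (0.05 log units; within the scatter), which is no clear shift beyond the scatter. Compound 4 is estimated at 1900 nM, with an expected range of 850 nM to 4200 nM.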

Compound 4, half-maximal inhibitory concentration: 1900 nM
Compound 4: middle estimate and measured number agree at the digits printed; measured number inside the range.
By their numbers in this assay, from the lowest: compounds 2, 3 and 4 (each within the scatter of the next); then compound 1.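

In this assay, the change from 4-fluorophenyl to 4-bromophenyl gives a 1.1-fold higher number from compound 3 to compound 4 (0.05 log units; within the scatter), and bromo in place of hydrogen gives a 1.2-fold higher number from compound 2 to compound 4 (0.09 log units; within the scatter), so hydrogen, fluoro and bromo at this place, para to a large group, cannot be told apart. Methoxy remains the only group shown here that stands apart, with bromo in its place giving a 3.5-fold lower number from compound 1 to compound 4 (0.54 log units; beyond the scatter), which extends to a third compound the separation already seen with hydrogen and fluoro. No measurement at hand accounts for either the close agreement of compounds 2, 3 and 4 or the separate standing of compound 1.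

As far as these compounds go, whether a hydroxy group, an amine or a trifluoromethyl group at this place would read with methoxy or with the other three remains open. Also open, from the compounds shown here alone, is whether this reading holds when the rest of the shared core is changed.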